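The source may hold more compounds than are shown below. What is called first, only, known or untested is meant among the compounds shown, and "the series" means these compounds.

Measured so far:
compound 1 `Cc1ccc(C(=O)NCc2ccccc2C(F)(F)F)cc1C#CC(C)N(O)C(N)=O`: 1700 nM
compound 2 `CC(C#Cc1cccc(C(=O)NCc2cccc(F)c2)c1)N(O)C(N)=O`: 4000 nM
compound 3 `CCCC(C#Cc1cccc(C(=O)NCc2ccccc2C(F)(F)F)c1)N(O)C(N)=O`: 300 nM

In an assay for inhibition of Polyunsaturated fatty acid 5-lipoxygenase (Homo sapiens), read by HPLC, with stated times of 15 min and 10 min (on this read-out lower numbers stand for stronger inhibition and higher numbers for weaker inhibition), compound 3 gives the lowest of the three numbers; compound 1 sits nearest, with a higher number beyond the scatter, and compound 2 furthest, also beyond the scatter. Compound 4 `C[C@@H](C#Cc1cccc(C(=O)NCc2ccccc2C(F)(F)F)c1)N(O)C(N)=O` is not yet measured. It differs from compound 3 in one place: 1-(carbamoyl(hydroxy)amino)ethyl in place of 1-(carbamoyl(hydroxy)amino)butyl on a triple-bonded carbon. Among the compounds with values here, the shorter chain with a defined stereocentre has no measured counterpart on this core, so the step is an estimate. Compound 1, which carries the ethyl chain on a differently substituted core, gives 1700 nM, a weaker number than compound 3 gives; on that basis a moderate weakening in this assay is expected, a 2.7-fold higher number from compound 3 to compound 4 (0.43 log units; beyond the scatter). Compound 4 is therefore expected at about 800 nM, with a likely range of 250 nM to 2500 nM.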

Compound 4, half-maximal inhibitory concentration: 700 nM
Beside the measured number, compound 4's estimate is 1.1-fold (0.06 log units) above it; the range from low to high includes it.
By their numbers in this assay, from the lowest: compound 3; then compound 4; then compound 1; then compound 2.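

In this assay, within the data shown here, the change to 1-(carbamoyl(hydroxy)amino)ethyl from 1-(carbamoyl(hydroxy)amino)butyl on a triple-bonded carbon gives a 2.3-fold higher number from compound 3 to compound 4 (0.37 log units; beyond the scatter) and is the first one-place reading at this position. The step is modest. The entering group also brings one defined stereocentre, and chain length and stereocentre are read together here. No measurement on hand accounts for the step.

Still open, from the compounds shown here alone, are the mirror-image form of compound 4 and how a longer chain, such as 1-(carbamoyl(hydroxy)amino)hexyl, behaves at this position. The separate contribution of the stereocentre also remains unresolved.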